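Anilide versus sulfonamide: a chloro-to-acetyl swap assessed

This account rests on a few compounds, and the source may have more. Where it says the series, first, only, none or still open, it means among the compounds named here.

Measured compounds:
compound 1 `COc1ccc(Oc2ccc([N+](=O)[O-])cc2C(=O)Nc2ccc(Cl)cc2)cc1`, 10100 nM
compound 2 `CC(C)NC1=NS(=O)(=O)c2cc(Cl)ccc2N1`, 250 nM

In a functional assay (Homo sapiens) for inhibition, using a membrane potential dye, in the presence of a further agent that is not named here (on this read-out higher numbers stand for weaker inhibition and lower numbers for stronger inhibition), compound 1 gives 10100 nM, the highest of the two numbers recorded. Compound 2, built on a different core, gives 250 nM in this assay, a lower number by a gap that lies well beyond the usual scatter. Among the compounds with values here, no single-point step between the two measured compounds exists, so compound 2 offers no direct guide for a change on the core of compound 1.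

Compound 3 `COc1ccc(Oc2ccc([N+](=O)[O-])cc2C(=O)Nc2ccc(C(C)=O)cc2)cc1` is the next compound in this assay. It differs from compound 1 in one place: acetyl in place of chloro on an aromatic carbon. The change sits far from the nitro-bearing ring and adds only a small acceptor-bearing group in place of a halogen. Within the data shown here, with no comparable measured step available, the expected step in this assay is a 1.0-fold lower number from compound 1 to compound 3 (0.00 log units; within the scatter), small and not clearly beyond the scatter. Compound 3 is therefore estimated at 10000 nM, with a range from 3500 nM to 30000 nM.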

Compound 3, half-maximal inhibitory concentration: 8100 nM
Compound 3: middle estimate off by 1.2-fold (0.09 log units), on the high side; measured number inside the range.
By their numbers in this assay, from the lowest: compound 2; then compounds 3 and 1 (each within the scatter of the next).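

In this assay, the step is a 1.2-fold lower number from compound 1 to compound 3 (0.10 log units; within the scatter), so this place on the aromatic ring, para to a large group, accepts acetyl in place of chloro without a change that can be read. Within the data shown here, this is the first single-place comparison on the core of compound 1, and it shows that going from 1 heavy atom to 3, with 1 hydrogen-bond acceptor entering, leaves the read-out within the scatter. Nothing measured here bears on why the step is so small.

Going by these compounds, whether a group of another kind at this place, such as an amine or a carboxylic acid, would move the number beyond the scatter remains open. So does whether any change elsewhere on this core, such as a nitrile in place of the nitro group, would do so.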